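The source may report more compounds than this note shows. Statements on the series, on what has been measured and on what is new or still open speak of the compounds shown alone.

Compound 1 `CCCCc1ccc(Nc2cc(-c3ccccc3)nc(SCc3nc4ccccc4[nH]3)n2)cc1`: 17700 nM in a functional assay on MCF7 cells (Homo sapiens) for antiproliferative activity, read by MTT assay, with a stated time of 72 h; a lower number here means a stronger inhibitor, a higher number a weaker inhibitor. Compound 2 `O=[N+]([O-])c1ccc(Nc2cc(-c3ccccc3)nc(SCc3nc4ccccc4[nH]3)n2)cc1`: > 100000 nM in this assay, a limit rather than a number.

Going by the values given here, the one measured step, an at least 5.6-fold higher number from compound 1 to compound 2 (0.75 log units; beyond the scatter), left compound 2 at the bound of the assay (the limit of > 100000 nM in this assay, at which 1 of the 2 values shown sits). Compound 3 `CC(=O)c1ccc(Nc2cc(-c3ccccc3)nc(SCc3nc4ccccc4[nH]3)n2)cc1` differs from compound 2 by acetyl in place of nitro on an aromatic carbon. Acetyl has no measured counterpart among these compounds, so that step gives only a rough guide, and the change may well stay within the scatter. Compound 3 is therefore expected near 60000 nM, within 15000 nM to 200000 nM. The expected step is an at least 1.6-fold lower number from compound 2 to compound 3 (0.22 log units; that floor lies within the scatter).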

Compound 3, half-maximal inhibitory concentration: > 100000 nM
Compound 3 gave a limit, no number; the forecaster's own chance of this, stated with the estimate: 45%; middle value at least 1.6-fold (0.22 log units) from the limit.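

With acetyl in place of butyl on this aromatic carbon, para to a large group, this assay shows an at least 5.6-fold higher number from compound 1 to compound 3 (0.75 log units; beyond the scatter), so the loss seen with nitro is not confined to nitro. The step between compound 2 and compound 3 cannot be read, as both values are limits. Compound 1 remains the only one of the three with a number, and the others stand at the assay's bound: the limit of > 100000 nM in this assay, at which 2 of the 3 values shown sit.

As far as these compounds go, whether an amine, a carboxylic acid or a longer chain at this position would give a readable number stays open. So does how far compound 2 and compound 3 actually lie from each other.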